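Furanylmethyl ester follows aryl ester in a dopamine transporter series

A few compounds are considered here, and "the series" means these few. Any claim that something is new, unique, unknown or untested is made for them only; others in the source may bear on it.

In an assay on COS-1 cells for displacement of a labelled ligand from sodium-dependent dopamine transporter (Homo sapiens) (a lower number here means a stronger inhibitor, a higher number a weaker inhibitor), compound 1 `O=C(C1=C(c2ccc(Cl)c(Cl)c2)CCC1)N1CCCC1` gives 58000 nM, compound 2 `O=C(OCCF)C1=C(c2ccc(Cl)c(Cl)c2)CCC1` gives 500 nM and compound 3 `Cc1cccc(OC(=O)C2=C(c3ccc(Cl)c(Cl)c3)CCC2)c1` gives 60 nM. The steps were a 120-fold lower number from compound 1 to compound 2 (2.06 log units; beyond the scatter) and an 8.3-fold lower number from compound 2 to compound 3 (0.92 log units; beyond the scatter); compound 3 therefore stands lowest of the three. Compound 4 `O=C(OCc1ccco1)C1=C(c2ccc(Cl)c(Cl)c2)CCC1` differs from compound 3 by (furan-2-yl)methyl in place of 3-methylphenyl on an oxygen next to a carbonyl group. Among the compounds with values here, only the step of an 8.3-fold lower number from compound 2 to compound 3 (0.92 log units; beyond the scatter) bears directly on this change, since it also swapped the group on the ester oxygen, and it was modest. The furanylmethyl group is neither aryl nor fluoroethyl, so a modest rise toward compound 2 is expected in this assay, with a 3.3-fold higher number from compound 3 to compound 4 (0.52 log units; beyond the scatter). Compound 4 is estimated at 200 nM, in the range 50 nM to 800 nM.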

Compound 4, inhibition constant: 1500 nM
Beside the measured number, compound 4's estimate is 7.5-fold (0.88 log units) below it; measured number outside the range, above it.
By their numbers in this assay, from the lowest: compound 3; then compound 2; then compound 4; then compound 1.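

In this assay, the group on an oxygen next to a carbonyl group proves able to move the number widely among aromatic groups, with a 25-fold higher number from compound 3 to compound 4 (1.40 log units; beyond the scatter). (Furan-2-yl)methyl also falls behind 2-fluoroethyl, with a 3.0-fold higher number from compound 2 to compound 4 (0.48 log units; beyond the scatter), yet it keeps much of the gain over pyrrolidin-1-yl on a carbonyl carbon, with a 39-fold lower number from compound 1 to compound 4 (1.59 log units; beyond the scatter). Nothing available explains these steps. As far as these compounds go, it remains open whether benzyl on this oxygen would stand nearer compound 3 or compound 4, which would separate the effect of the ring from that of the chain carbon carrying it.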